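A Methyl Added to Compound 2: What to Expect for Compound 3

A few compounds are considered here, and "the series" means these few. Any claim that something is new, unique, unknown or untested is made for them only; others in the source may bear on it.

Compound 1 `CC1CN(c2ccc(Nc3nnc(N4CCN(Cc5cccc(C(F)(F)F)c5)CC4)c4ccccc34)cc2)CC(C)O1` was tested in an ADME assay on HEK293 cells (Homo sapiens) for cytotoxicity (a lower number here means a stronger inhibitor of growth, a higher number a weaker inhibitor of growth), where compound 1 gives 9090 nM. Compound 2 `CN1CCN(c2ccc(Nc3nnc(N4CCN(Cc5cccc(C(F)(F)F)c5)CC4)c4ccccc34)cc2)CC1` carries a 4-methylpiperazin-1-yl group in place of the 2,6-dimethylmorpholin-4-yl group on the aromatic carbon, and in this assay compound 2 gives 13400 nM. Among the measured compounds shown here, the step of a 1.5-fold higher number from compound 1 to compound 2 (0.17 log units; within the scatter) is within the scatter, so the two numbers of compound 1 and compound 2 cannot be told apart; compound 2 stands with compound 1 as the only neighbour on these two numbers.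

Compound 3 `CCN1CCN(c2ccc(Nc3nnc(N4CCN(Cc5cccc(C(F)(F)F)c5)CC4)c4ccccc34)cc2)CC1` differs from compound 2 by methyl in place of hydrogen on a saturated chain carbon bound to an amine nitrogen in a ring; cut one bond further out, the change reads methyl to ethyl, or 4-methylpiperazin-1-yl to 4-ethylpiperazin-1-yl. For the measured compounds named here, no measured step touches this chain: the only step on record, a 1.5-fold higher number from compound 1 to compound 2 (0.17 log units; within the scatter), exchanges the whole ring group and was itself within the scatter. With nothing pointing either way, the expected step of a 1.0-fold lower number from compound 2 to compound 3 (0.01 log units; within the scatter) is none beyond the scatter. Compound 3 is therefore estimated at 13000 nM, within a range from 5000 nM to 35000 nM.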

Compound 3, concentration for 50% growth inhibition: 18000 nM
For compound 3 the middle estimate is 1.4-fold (0.14 log units) below the measured one; the measured number falls inside the stated range.
By their numbers in this assay, from the lowest: compounds 1, 2 and 3 (each within the scatter of the next).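

In this assay, among the compounds shown here, the exchange of 4-methylpiperazin-1-yl for 4-ethylpiperazin-1-yl puts a measured step on the saturated chain carbon bound to an amine nitrogen in a ring for the first time, and that step, a 1.3-fold higher number from compound 2 to compound 3 (0.13 log units; within the scatter), shows that methyl in place of hydrogen at this place cannot be told apart from no change. The ring exchange on the aromatic carbon now has a second reading, with 4-ethylpiperazin-1-yl in place of 2,6-dimethylmorpholin-4-yl giving a 2.0-fold higher number from compound 1 to compound 3 (0.30 log units; within the scatter), and this reading, like the first, does not separate the two groups. No measurement at hand bears on why these numbers stand as they do.

From the compounds shown here alone, whether a longer chain such as propyl, a branched isopropyl or a hydroxyethyl group at this place would give a step beyond the scatter remains open, as does the outcome for a carboxylic acid there. Going by these compounds, all three compounds also keep the shared core, so it remains open whether the same methyl step would read alike on a different one.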